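Compound 3 to compound 4: swapping the aryl group

The source may hold more compounds than are shown below. What is called first, only, known or untested is meant among the compounds shown, and "the series" means these compounds.

In a functional assay on SGC-7901 cells (Homo sapiens) for antiproliferative activity, read by MTT assay, with a stated time of 72 h (on this read-out lower numbers stand for stronger inhibition and higher numbers for weaker inhibition), three aryl variants on the shared core have been measured. Compound 1 (`COc1ccccc1-c1ccc2ncn(-c3cc(OC)c(OC)c(OC)c3)c2c1`) gives 5050 nM, compound 2 (`COc1ccc(-c2ccc3ncn(-c4cc(OC)c(OC)c(OC)c4)c3c2)cc1O`) gives 44 nM, and compound 3 (`COc1ccc(-c2ccc3ncn(-c4cc(OC)c(OC)c(OC)c4)c3c2)cc1F`) gives 430 nM. Compound 3 therefore holds the second highest of the three numbers, between the other two.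

The next change leads to compound 4 (`COc1cc(-n2cnc3ccc(-c4ccc([N+](=O)[O-])cc4)cc32)cc(OC)c1OC`), with 4-nitrophenyl in place of 3-fluoro-4-methoxyphenyl on an aromatic carbon.

All three measured steps concern this same place. The two large ones are a 110-fold lower number from compound 1 to compound 2 (2.06 log units; beyond the scatter) and a 12-fold lower number from compound 1 to compound 3 (1.07 log units; beyond the scatter), so replacing the whole aryl group has moved the number a long way in this small set. The modest 9.8-fold higher number from compound 2 to compound 3 (0.99 log units; beyond the scatter) comes from exchanging fluoro for hydroxy alone. Within the data shown here, no measured compound carries a nitro group, and compound 4 lacks the methoxy group shared by compound 2 and compound 3. Those two hold the two lowest numbers, with compound 2 at 44 nM and compound 3 at 430 nM.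

A modest rise in this assay is therefore expected, with wide uncertainty. The expected change is a 3.0-fold higher number from compound 3 to compound 4 (0.48 log units; beyond the scatter). For compound 4 the estimate is 1300 nM, within an expected range of 250 nM to 5500 nM.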

Compound 4, half-maximal inhibitory concentration: 79 nM
Beside the measured number, compound 4's estimate is 16-fold (1.22 log units) above it; measured number outside the range, below it.
By their numbers in this assay, from the lowest: compounds 2 and 4 (each within the scatter of the next); then compound 3; then compound 1.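

Working notes on the aryl position: in this assay, a methoxy group on this aryl group is not required for a low number, as 4-nitrophenyl, which carries none, gives a 5.4-fold lower number from compound 3 to compound 4 (0.74 log units; beyond the scatter) and a 64-fold lower number from compound 1 to compound 4 (1.81 log units; beyond the scatter) on the shared core. Compared with the 3-hydroxy-4-methoxyphenyl group, 4-nitrophenyl gives a 1.8-fold higher number from compound 2 to compound 4 (0.25 log units; within the scatter), so these two aryl groups cannot be told apart in this read-out, and a hydroxy group is not the only substituent among these compounds that reaches this range. No available evidence accounts for these differences.

The compounds shown leave open whether the low number of compound 4 belongs to the nitro group itself, or whether an amine, a nitrile or a carboxylic acid at the same ring carbon would give a similar number. They also leave open how a nitro group placed elsewhere on that ring would behave, and how a plain phenyl group would compare with the substituted aryl groups.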